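Fluorine Added to the Bromophenyl Arm of Compound 3

A few compounds are considered here, and "the series" means these few. Any claim that something is new, unique, unknown or untested is made for them only; others in the source may bear on it.

Three compounds share one core and differ only in the ring attached to its nitrogen. Compound 1 `O=C(Nc1ccc(Oc2ncnc3[nH]ccc23)c(F)c1)c1cc2cccnc2n(-c2ccccc2)c1=O` bears an unsubstituted phenyl; in a functional assay on HeLa cells (Homo sapiens) for cytotoxicity, read by MTT assay, with a stated time of 72 h (a higher number here means a weaker inhibitor, a lower number a stronger inhibitor), compound 1 gives 36900 nM. Compound 2 `O=C(Nc1ccc(Oc2ncnc3[nH]ccc23)c(F)c1)c1cc2cccnc2n(-c2ccc(F)cc2)c1=O` carries fluoro in place of hydrogen on an aromatic carbon, and in this assay compound 2 gives 3720 nM; this change produced a 9.9-fold lower number from compound 1 to compound 2 (1.00 log units; beyond the scatter). Compound 3 `O=C(Nc1ccc(Oc2ncnc3[nH]ccc23)c(F)c1)c1cc2cccnc2n(-c2ccc(Br)cc2)c1=O` differs from compound 1 by bromo in place of hydrogen on an aromatic carbon; in this assay compound 3 gives 19900 nM, and the step of a 1.9-fold lower number from compound 1 to compound 3 (0.27 log units; within the scatter) is small, while a 5.3-fold higher number from compound 2 to compound 3 (0.73 log units; beyond the scatter) is a modest step.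

Compound 4 `O=C(Nc1ccc(Oc2ncnc3[nH]ccc23)c(F)c1)c1cc2cccnc2n(-c2ccc(Br)cc2F)c1=O` has not been measured. It differs from compound 3 by fluoro in place of hydrogen on an aromatic carbon. Within the data shown here, this is the same kind of change as the one made from compound 1 to compound 2, but not the same: there the fluoro entered para to a large group, here it enters ortho to a large group and meta to a bromo group, and the two cores differ by bromo in place of hydrogen on an aromatic carbon. Because a 9.9-fold lower number from compound 1 to compound 2 (1.00 log units; beyond the scatter) showed a fluoro lowering the number, a step in the same direction is expected, though smaller given the different place: the expected step is a 3.1-fold lower number from compound 3 to compound 4 (0.49 log units; beyond the scatter). Compound 4 is estimated at 6500 nM, between 1500 nM and 25000 nM.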

Compound 4, half-maximal inhibitory concentration: 87800 nM
For compound 4 the middle estimate is 14-fold (1.13 log units) below the measured one, and the stated range ends below it.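

In this assay, fluoro in place of hydrogen on an aromatic carbon does not carry over from the core of compound 1 to the core of compound 3, where the step is a 4.4-fold higher number from compound 3 to compound 4 (0.64 log units; beyond the scatter), and the two steps differ when set side by side: the same change on two cores in this assay, a 9.9-fold lower number (1.00 log units; beyond the scatter) from compound 1 to compound 2 and a 4.4-fold higher number (0.64 log units; beyond the scatter) from compound 3 to compound 4, 44-fold (1.64 log units) apart, beyond the scatter of two such steps. The 4-bromo-2-fluorophenyl group also gives a 24-fold higher number from compound 2 to compound 4 (1.37 log units; beyond the scatter) and a 2.4-fold higher number from compound 1 to compound 4 (0.38 log units; beyond the scatter). This shows that the effect of the fluoro on this arm cannot be assumed from one core to the next, but it does not show why, since the two fluoro steps differ both in the fluoro's place and in the presence of the bromo, and each rests on a single pair.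

The compounds shown leave open what a fluoro ortho to a large group would do on the unsubstituted phenyl of compound 1, which would separate place from the bromo. They also leave open whether a chloro or a methoxy group in place of the bromo would give the same reversal.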